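Notes: halogen to trifluoromethyl on the pendant phenyl ring

The compounds below may be only part of what the source reports. "The series", "measured", "known", "first", "only" and "open" are said of these compounds alone.

Measured so far in a functional assay on A549 cells (Homo sapiens) for cytotoxicity, read by MTT assay, with a stated time of 72 h; on this read-out higher numbers stand for weaker inhibition and lower numbers for stronger inhibition:
compound 1 `O=C(Nc1ccc(Oc2ccnc3[nH]ccc23)cc1)c1cc(-c2ccc(F)cc2)ncn1`: 13000 nM
compound 2 `O=C(Nc1ccc(Oc2ccnc3[nH]ccc23)cc1)c1cc(-c2ccc(Cl)cc2)ncn1`: 6530 nM

Compound 2 carries the lower of the two numbers, but the step of a 2.0-fold lower number from compound 1 to compound 2 (0.30 log units; within the scatter) is within the scatter, so compound 2 is not separated from compound 1 on this read-out.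

Compound 3 `O=C(Nc1ccc(Oc2ccnc3[nH]ccc23)cc1)c1cc(-c2ccc(C(F)(F)F)cc2)ncn1` differs from compound 2 by trifluoromethyl in place of chloro on an aromatic carbon. For the measured compounds named here, the only measured step touching this carbon is the fluoro-to-chloro exchange from compound 1 to compound 2, and it stayed within the scatter; no measured step covers a trifluoromethyl group anywhere. The expectation for compound 3 is therefore a step of about a 1.2-fold lower number from compound 2 to compound 3 (0.07 log units; within the scatter) in this assay, in either direction, and not clearly beyond the scatter. Compound 3 is estimated at 5500 nM, with a range from 1500 nM to 18000 nM.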

Compound 3, half-maximal inhibitory concentration: 9380 nM
Beside the measured number, compound 3's estimate is 1.7-fold (0.23 log units) below it; measured number inside the range.
By their numbers in this assay, from the lowest: compounds 2, 3 and 1 (each within the scatter of the next).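

In this assay the change from 4-chlorophenyl to 4-(trifluoromethyl)phenyl gives a 1.4-fold higher number from compound 2 to compound 3 (0.16 log units; within the scatter) and trifluoromethyl in place of fluoro on the same aromatic carbon gives a 1.4-fold lower number from compound 1 to compound 3 (0.14 log units; within the scatter) on this read-out. A group of several heavy atoms is thus tolerated at this carbon as well as a single halogen atom, and fluoro, chloro and trifluoromethyl are not separated from one another here. No data are available to explain this flat result. On these data alone, all three groups contain halogen and sit on the same carbon, so it remains open whether an amine, a carboxylic acid or a longer alkyl chain there would move the number beyond the scatter. Also open, as far as these compounds go, is whether changes elsewhere on the shared core would do so.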